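A few compounds are considered here, and "the series" means these few. Any claim that something is new, unique, unknown or untested is made for them only; others in the source may bear on it.

Working notes on the shared core of compound 1 `COc1ccc(-n2cc(CN3C(=O)C[C@@H]4CC[C@@]3(C)C4(C)C)nn2)cc1` in a functional assay on OVCAR-3 cells (Homo sapiens) for inhibition, read by MTT assay, with a stated time of 24 h; on this read-out higher numbers stand for weaker inhibition and lower numbers for stronger inhibition. Compound 1 gives 250 nM. Compound 2 `CC1(C)[C@H]2CC[C@]1(C)N(Cc1cn(-c3ccccc3Br)nn1)C(=O)C2` gives 140 nM, and compound 3 `CC1(C)[C@H]2CC[C@]1(C)N(Cc1cn(-c3cccc(O)c3)nn1)C(=O)C2` gives 370 nM, the highest of the three numbers. From compound 1 the step to compound 3 is a 1.5-fold higher number from compound 1 to compound 3 (0.17 log units; within the scatter), so these two cannot be ordered; the step of a 2.6-fold higher number from compound 2 to compound 3 (0.42 log units; beyond the scatter) is the only one here that stands beyond the scatter.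

Compound 4 `CC1(C)[C@H]2CC[C@]1(C)N(Cc1cn(-c3ccccc3F)nn1)C(=O)C2` carries 2-fluorophenyl in place of 3-hydroxyphenyl on an aromatic nitrogen. For the measured compounds named here, no measured pair covers 2-fluorophenyl itself. The step that bears most on it is a 2.6-fold higher number from compound 2 to compound 3 (0.42 log units; beyond the scatter), in which a 2-bromophenyl left and a 3-hydroxyphenyl entered; compound 4 undoes that exchange with a 2-fluorophenyl instead. On these data alone, the 2-fluorophenyl and the 2-bromophenyl are both named for the same ring position in the structures, so a lower number is expected, of about the size seen in that pair, with wide uncertainty since the fluorine case is untested. Compound 4 is therefore estimated at 180 nM, between 80 nM and 400 nM, a step of a 2.1-fold lower number from compound 3 to compound 4 (0.31 log units; beyond the scatter).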

Compound 4, half-maximal inhibitory concentration: 300 nM
The estimate for compound 4 lay 1.7-fold (0.22 log units) below the measured number; measured number inside the range.
By their numbers in this assay, from the lowest: compounds 2, 1, 4 and 3 (each within the scatter of the next, the first and the last beyond it).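

In this assay, for the compounds shown here, the halogen exchange gives the one new step beyond the scatter: a 2.1-fold higher number from compound 2 to compound 4 (0.33 log units; beyond the scatter) with fluoro in place of bromo on an aromatic carbon, so the two halogens are not interchangeable at this place. Swapping the 3-hydroxyphenyl for the 2-fluorophenyl shows no separation, with a 1.2-fold lower number from compound 3 to compound 4 (0.09 log units; within the scatter) and likewise a 1.2-fold higher number from compound 1 to compound 4 (0.08 log units; within the scatter) for the change from 4-methoxyphenyl, and the loss of the hydrogen-bond donor counted on 3-hydroxyphenyl therefore leaves no readable change. The data at hand give no measured basis for explaining the gap between the bromo and fluoro compounds.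

On these data alone, what a 2-chlorophenyl or a 2-aminophenyl group would give on this nitrogen remains open. As far as these compounds go, whether the difference between bromo and fluoro carries over to other ring positions also remains open.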